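The source may report more compounds than this note shows. Statements on the series, on what has been measured and on what is new or still open speak of the compounds shown alone.

Measured compounds:
- compound 1, `CC(C)c1ccc(NC(=O)[C@H]2CN(C)C[C@@H]2c2ccc(/C=C/C(=O)Nc3ccccc3N)cc2)cc1`: 54 mL/min/kg
- compound 2, `CN1C[C@H](C(=O)Nc2ccccc2F)[C@@H](c2ccc(/C=C/C(=O)Nc3ccccc3N)cc2)C1`: 67 mL/min/kg

In an in vitro ADME assay on microsomes from liver (Mus musculus) for pharmacokinetics, read by LC-MS, with a stated time of 10 min, tested at 1 uM (a higher number here means faster removal of the compound, a lower number slower removal), compound 1 gives 54 mL/min/kg and compound 2 gives 67 mL/min/kg. Within the data shown here, only two compounds have been measured, and they differ in one place: 2-fluorophenyl in place of 4-isopropylphenyl on an amide-type nitrogen, with the step of a 1.2-fold higher number from compound 1 to compound 2 (0.09 log units; within the scatter). Compound 2 therefore does not stand apart from compound 1 in this assay; the two numbers lie within the scatter of each other.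

Compound 3, `CN1C[C@H](C(=O)Nc2ccccn2)[C@@H](c2ccc(/C=C/C(=O)Nc3ccccc3N)cc2)C1`, has not yet been measured. It differs from compound 2 as follows: pyridin-2-yl in place of 2-fluorophenyl on an amide-type nitrogen. Among the measured compounds shown here, the only measured step, between compound 1 and compound 2, also exchanges the group on this amide-type nitrogen, and it stayed within the scatter. For the measured compounds named here, no measured step covers the exchange of a phenyl ring for a pyridin-2-yl ring here, so the expectation rests on that single step alone.

On that basis compound 3 is expected to give a number close to compound 2, with a step of a 1.1-fold lower number from compound 2 to compound 3 (0.05 log units; within the scatter) that is estimated to stay within the scatter. The estimate for compound 3 in this assay is 60 mL/min/kg, with a range from 32 mL/min/kg to 115 mL/min/kg.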

Compound 3, clearance: 40 mL/min/kg
Compound 3: the middle estimate sits 1.5-fold (0.18 log units) above what was measured; the range from low to high includes it.
By their numbers in this assay, from the lowest: compounds 3, 1 and 2 (each within the scatter of the next).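

In this assay, putting pyridin-2-yl on the amide-type nitrogen gives a 1.7-fold lower number from compound 2 to compound 3 (0.22 log units; within the scatter), and the same group gives a 1.4-fold lower number from compound 1 to compound 3 (0.13 log units; within the scatter). Among these compounds, this extends the earlier picture, which held only two aromatic rings of carbon alone, to a six-membered aromatic ring with a hetero atom: all three groups at this place now lie within the scatter of each other, even though the step from the 2-fluorophenyl compound is the largest of the three read here. No information is available that would account for these numbers.

The compounds shown leave open whether any group on this nitrogen would move the clearance beyond the scatter, since all three are six-membered aromatic rings; a saturated cyclohexyl ring, a straight alkyl chain or a phenyl ring carrying a carboxylic acid or an amine could answer that. They also leave open whether pyridin-3-yl or pyridin-4-yl would behave like pyridin-2-yl, and whether changes elsewhere on the shared core would matter more than changes at this place.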